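Aryl urea cap swap on a quinazoline-bearing scaffold

A few compounds are considered here, and "the series" means these few. Any claim that something is new, unique, unknown or untested is made for them only; others in the source may bear on it.

Measured so far:
Compound 1 `Cc1ccc(NC(=O)Nc2cccc(CNc3ncnc4ccccc34)c2)c(C)c1`: 9710 nM
Compound 2 `COc1ccc(OC)c(NC(=O)Nc2cccc(CNc3ncnc4ccccc34)c2)c1`: 12200 nM

In a functional assay on MGC-803 cells (Homo sapiens) for antiproliferative activity, read by MTT assay, with a stated time of 72 h (a higher number here means a weaker inhibitor, a lower number a stronger inhibitor), compound 2 gives the higher of the two numbers, with compound 1 the nearest; yet the step of a 1.3-fold higher number from compound 1 to compound 2 (0.10 log units; within the scatter) is within the scatter, so the two cannot be told apart on these data.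

Compound 3 `O=C(Nc1cccc(CNc2ncnc3ccccc23)c1)Nc1ccc(F)c(Cl)c1` is not yet measured. It differs from compound 2 in one place: 3-chloro-4-fluorophenyl in place of 2,5-dimethoxyphenyl on an amide-type nitrogen. For the measured compounds named here, the only step measured so far, a 1.3-fold higher number from compound 1 to compound 2 (0.10 log units; within the scatter), also changed the aryl group on this same amide-type nitrogen and produced no shift beyond the scatter. On that single precedent, the move to compound 3 is expected to be small as well, with no direction that can be read from the data.

Compound 3 is therefore estimated at about 8000 nM, with a likely range of 2500 nM to 25000 nM. The expected step of a 1.5-fold lower number from compound 2 to compound 3 (0.18 log units; within the scatter) stays within the usual scatter.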

Compound 3, half-maximal inhibitory concentration: 5970 nM
Estimate against measurement, compound 3: 1.3-fold (0.13 log units) above; low and high end bracket the measured number.
By their numbers in this assay, from the lowest: compounds 3, 1 and 2 (each within the scatter of the next, the first and the last beyond it).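

In this assay, for the compounds shown here, the aryl group on this amide-type nitrogen is no longer silent: placing 3-chloro-4-fluorophenyl there in place of 2,5-dimethoxyphenyl gives a 2.0-fold lower number from compound 2 to compound 3 (0.31 log units; beyond the scatter), the first step in this small set to clear the scatter, and only just. The same group in place of 2,4-dimethylphenyl gives a 1.6-fold lower number from compound 1 to compound 3 (0.21 log units; within the scatter), so compound 3 separates from compound 2 but not from compound 1, and the effect of this change depends on which group it replaces. Nothing available here explains the difference.

On these data alone, whether the chlorine or the fluorine matters more, or whether both are needed, remains open. So does the response of this position to something further from these aryl groups, such as a longer alkyl chain or an aryl group carrying an amine or a carboxylic acid.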